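Oxygen to Sulfur on a Dichlorophenyl Linker

The source may report more compounds than this note shows. Statements on the series, on what has been measured and on what is new or still open speak of the compounds shown alone.

Measured compounds in this assay:
compound 1, `Nc1cc(N)c2nc(-c3ccccc3)c(Oc3ccc(Cl)c(Cl)c3)nc2c1`: 63100 nM
compound 2, `CCOC(=O)[C@H](CCC(=O)O)NC(=O)c1ccc(Sc2nc3cc(N)cc(N)c3nc2-c2ccccc2)cc1`: < 100000 nM

Within the data shown here, in a functional assay on TK-10 cells (Homo sapiens) for inhibition, read by sulforhodamine B assay, with a stated time of 48 h (on this read-out higher numbers stand for weaker inhibition of growth and lower numbers for stronger inhibition of growth), compound 1 gives 63100 nM and is the only compound with a number rather than a limit. Compound 2 sits at the limit of < 100000 nM in this assay, at which 1 of the 2 values shown sits, which is a limit of the assay and not a measured number. Among the measured compounds shown here, no two measured compounds differ in a single place, so no measured step exists to set the size of the change now considered.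

Compound 3 has the structure `Nc1cc(N)c2nc(-c3ccccc3)c(Sc3ccc(Cl)c(Cl)c3)nc2c1`. It differs from compound 1 by (3,4-dichlorophenyl)sulfanyl in place of 3,4-dichlorophenoxy on an aromatic carbon. The single atom exchanged in the linker keeps the group count, ring count and hydrogen-bond pattern unchanged, and nothing measured here speaks for a change beyond the usual scatter in either direction.

Compound 3 is therefore expected near 56000 nM in this assay, with a likely range from 18000 nM to 160000 nM. That estimate amounts to an expected step of a 1.1-fold lower number from compound 1 to compound 3 (0.05 log units; within the scatter), no larger than the scatter of repeated measurements, with some chance that only a limit is reported.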

Compound 3, concentration for total growth inhibition: 20000 nM
Beside the measured number, compound 3's estimate is 2.8-fold (0.45 log units) above it, and the stated range covers the measured number.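

In this assay, among these compounds, placing (3,4-dichlorophenyl)sulfanyl instead of 3,4-dichlorophenoxy on the aromatic carbon next to the ring nitrogen gives a 3.2-fold lower number from compound 1 to compound 3 (0.50 log units; beyond the scatter), the first measured step at this position. The count of heavy atoms, the aromatic ring, the hydrogen-bond donors and acceptors and the net charge of the group are the same on both sides. The exchange of oxygen for sulfur in the linker is the only difference between the two compounds, and the lower number stands for stronger inhibition of growth. The step rests on this single pair, and nothing measured here accounts for it.

From the compounds shown here alone, it remains open whether an amine or a methylene linker in the same place would read closer to compound 1 or to compound 3. Going by these compounds, it is equally open whether the step would persist with a sulfonyl linker, or with a carboxylic acid or a longer chain in place of the two chlorine atoms on the outer ring.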